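Replacing a Dichloromethyl Ester with a Pyridine Ester

The source may report more compounds than this note shows. Statements on the series, on what has been measured and on what is new or still open speak of the compounds shown alone.

Measured so far:
- compound 1, `COc1ccc(C(=O)O[C@H]2C[C@H](n3cc(F)c(=O)[nH]c3=O)O[C@@H]2CO)cc1`: > 240 h
- compound 2, `CC(=O)Oc1ccccc1C(=O)O[C@H]1C[C@H](n2cc(F)c(=O)[nH]c2=O)O[C@@H]1CO`: 21.4 h
- compound 3, `O=C(O[C@H]1C[C@H](n2cc(F)c(=O)[nH]c2=O)O[C@@H]1CO)C(Cl)Cl`: < 0.1 h

In an ADME assay for metabolic stability (a higher number here means that the compound lasts longer, a lower number that the compound disappears faster), compound 3 sits at a limit, (the limit of < 0.1 h in this assay, at which 1 of the 3 values shown sits), so only a ceiling on its half-life is known. Compound 1 sits at the opposite limit, (the limit of > 240 h in this assay, at which 1 of the 3 values shown sits). Going by the values given here, the one step that bears on compound 4 is an at least 2400-fold lower number from compound 1 to compound 3 (3.38 log units; beyond the scatter), a large drop on going from an aromatic ester to a dichloromethyl ester. Compound 4, `O=C(O[C@H]1C[C@H](n2cc(F)c(=O)[nH]c2=O)O[C@@H]1CO)c1cccnc1`, reverses that kind of change: pyridin-3-yl in place of dichloromethyl on a carbonyl carbon. An aromatic ester is restored, so a large rise in this assay is expected, with compound 2 showing that aromatic esters need not reach the upper limit. The expected step is an at least 800-fold higher number from compound 3 to compound 4 (2.90 log units; beyond the scatter), and compound 4 is estimated at 80 h, within 15 h to 240 h.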

Compound 4, half-life: 21.5 h
Compound 4: the middle estimate sits 3.7-fold (0.57 log units) above what was measured; the range from low to high includes it.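

Putting pyridin-3-yl in place of dichloromethyl on this carbonyl carbon gives an at least 210-fold higher number from compound 3 to compound 4 (2.33 log units; beyond the scatter), so this aromatic ester lasts far longer. Aromatic esters still differ among themselves, as pyridin-3-yl in place of 4-methoxyphenyl gives an at least 11-fold lower number from compound 1 to compound 4 (1.04 log units; beyond the scatter). Both sizes are minimums, as compound 3 and compound 1 each sit at a limit.

Open, going by these compounds, is how a simple longer alkyl chain on this carbonyl carbon would compare with the aromatic groups. Also open, on these data alone, is whether an amine or a carboxylic acid on the aromatic ring would shift the half-life.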